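Swapping Nitro for Methoxy on the Benzyl Ring

The source may report more compounds than this note shows. Statements on the series, on what has been measured and on what is new or still open speak of the compounds shown alone.

Three compounds share one core and were measured in an assay on CHO cells for displacement of a labelled ligand from Alpha-1A adrenergic receptor (Homo sapiens); a lower number here means a stronger inhibitor, a higher number a weaker inhibitor:
compound 1 `COc1cccc(OC)c1OCCNCCOc1ccccc1OCc1ccccc1Cl` gives 1.41 nM
compound 2 `COc1cccc(OC)c1OCCNCCOc1ccccc1OCc1cccc(Cl)c1` gives 0.251 nM
compound 3 `COc1cccc(OC)c1OCCNCCOc1ccccc1OCc1ccc([N+](=O)[O-])cc1` gives 1.26 nM

Compound 3 holds the second highest number of the three. Its value and that of compound 1 lie within the scatter of each other, as a 1.1-fold lower number from compound 1 to compound 3 (0.05 log units; within the scatter) shows, while the step of a 5.0-fold higher number from compound 2 to compound 3 (0.70 log units; beyond the scatter) is beyond the scatter, so compound 2 stands apart with the lowest number. The step to compound 4 `COc1ccc(COc2ccccc2OCCNCCOc2c(OC)cccc2OC)cc1` is methoxy in place of nitro on an aromatic carbon. Within the data shown here, no measured step tests this exchange: the two known steps, a 5.6-fold lower number from compound 1 to compound 2 (0.75 log units; beyond the scatter) and a 5.0-fold higher number from compound 2 to compound 3 (0.70 log units; beyond the scatter), both concern where a chlorine sits or a change to nitro, and both are modest. With nothing pointing either way, compound 4 is expected to give a number close to that of compound 3, a step of a 1.2-fold higher number from compound 3 to compound 4 (0.08 log units; within the scatter), estimated at 1.5 nM with a range from 0.5 nM to 4.5 nM.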

Compound 4, inhibition constant: 2 nM
The estimate for compound 4 lay 1.3-fold (0.12 log units) below the measured number; the measured number falls inside the stated range.
By their numbers in this assay, from the lowest: compound 2; then compounds 3, 1 and 4 (each within the scatter of the next).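

In this assay, methoxy in place of nitro on this aromatic carbon, para to a large group, leaves the number within the scatter (a 1.6-fold higher number from compound 3 to compound 4 (0.20 log units; within the scatter)). The 4-methoxyphenyl of compound 4 is also within the scatter of the 2-chlorophenyl of compound 1 (a 1.4-fold higher number from compound 1 to compound 4 (0.15 log units; within the scatter)), whereas the 3-chlorophenyl of compound 2 stands apart (an 8.0-fold higher number from compound 2 to compound 4 (0.90 log units; beyond the scatter)). No measurement shown here explains these numbers. On these data alone, whether an amine or a carboxylic acid on this same carbon would also stay within the scatter remains open.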